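Para-substituent swap on the anilide: bromo to cyano

The compounds below may be only part of what the source reports. "The series", "measured", "known", "first", "only" and "open" are said of these compounds alone.

Measured compounds:
compound 1, `CCc1ccc(NC(=O)c2csc(Cc3c(Cl)cccc3Cl)n2)cc1`, 1450 nM
compound 2, `COc1ccc(NC(=O)c2csc(Cc3c(Cl)cccc3Cl)n2)cc1`, > 4000 nM
compound 3, `O=C(Nc1ccc(Br)cc1)c1csc(Cc2c(Cl)cccc2Cl)n1`, 460 nM

All three share one core and differ only in the group on the anilide ring. In an assay on CHO cells, read by calcium flux (a lower number here means a stronger inhibitor, a higher number a weaker inhibitor), compound 3 gives the lowest of the two numbers shown; compound 1 stands nearest, with a 3.2-fold lower number from compound 1 to compound 3 (0.50 log units; beyond the scatter) separating them. For compound 2 the assay reports only a limit, (the limit of > 4000 nM in this assay, at which 1 of the 3 values shown sits), so its value is not a number. The step of an at least 2.7-fold higher number from compound 1 to compound 2 (0.44 log units; beyond the scatter) and the step of an at least 8.6-fold lower number from compound 2 to compound 3 (0.93 log units; beyond the scatter) both lie beyond the scatter.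

Compound 4, `N#Cc1ccc(NC(=O)c2csc(Cc3c(Cl)cccc3Cl)n2)cc1`, differs from compound 3 by cyano in place of bromo on an aromatic carbon. Among the measured compounds shown here, no measured step replaces bromo with cyano, so the expectation rests on the spread of the three para groups already seen. Bromo gave the lowest number and the other two groups sat modestly to clearly higher, so a somewhat higher number is expected for compound 4, with a 2.6-fold higher number from compound 3 to compound 4 (0.42 log units; beyond the scatter) as the estimated step. The value of compound 4 in this assay is therefore estimated at 1200 nM, within a range from 400 nM to 4000 nM.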

Compound 4, half-maximal inhibitory concentration: 720 nM
Estimate against measurement, compound 4: 1.7-fold (0.22 log units) above, within the range that was stated.
By their numbers in this assay, from the lowest: compounds 3, 4 and 1 (each within the scatter of the next, the first and the last beyond it). At a limit, above all of these: compound 2.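

In this assay, the change from bromo to cyano at this position, which brings in a triple bond and a hydrogen-bond acceptor, stays within the scatter, with a 1.6-fold higher number from compound 3 to compound 4 (0.19 log units; within the scatter). The earlier compounds shown here had set bromo and ethyl apart, yet cyano cannot be separated from either of them, as a 2.0-fold lower number from compound 1 to compound 4 (0.30 log units; within the scatter) also lies within the scatter. Against methoxy the gap is beyond the scatter, an at least 5.5-fold lower number from compound 2 to compound 4 (0.74 log units; beyond the scatter), and that step rests on compound 2, whose value is a limit and not a number: the limit of > 4000 nM in this assay, at which 1 of the 4 values shown sits.

The compounds shown leave open what an amine, a carboxylic acid or a longer chain would do at this position. They also leave open whether these differences among the groups on the anilide ring would hold on a different core.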